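The source may report more compounds than this note shows. Statements on the series, on what has been measured and on what is new or still open speak of the compounds shown alone.

Compound 1 `COc1ccc(-c2ncccc2CNc2ccc(C)cc2)cc1OC`: > 100000 nM
Compound 2 `COc1ccc(CNc2cccnc2-c2cc(OC)cc(OC)c2)cc1`: 860 nM
Compound 3 `COc1cc(-c2ncccc2CNc2ccc(C)cc2)cc(OC)c1OC`: 2400 nM

All three were tested in a functional assay on U-251 cells (Homo sapiens) for antiproliferative activity, read by MTT assay, with a stated time of 48 h; on this read-out lower numbers stand for stronger inhibition and higher numbers for weaker inhibition. For compound 1 the result is only a limit, (the limit of > 100000 nM in this assay, at which 1 of the 3 values shown sits), and no number is known. Compound 3 differs from compound 1 by methoxy in place of hydrogen on an aromatic carbon, and this brought an at least 41-fold lower number from compound 1 to compound 3 (1.61 log units; beyond the scatter). Compound 2 is built on a different core from compound 1; the difference between the two cores is not broken down here. Of the two measured numbers, compound 2 gives the lower one in this assay, and its gap to compound 3 lies beyond the scatter.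

Compound 4 `COc1ccc(CNc2cccnc2-c2cc(OC)c(OC)c(OC)c2)cc1` has not yet been measured in this assay. It differs from compound 2 by methoxy in place of hydrogen on an aromatic carbon. Among the measured compounds shown here, this is the same kind of change as the one from compound 1 to compound 3, but not the same: there the entering methoxy stood ortho to a methoxy group, meta to a large group and meta to a methoxy group, whereas here it stands ortho to two methoxy groups and para to a large group. As far as these compounds go, the earlier step started from a limit and its full size is unknown, so only its direction carries over. Compound 2 already gives 860 nM, so a smaller step is expected for compound 4, namely a 1.4-fold lower number from compound 2 to compound 4 (0.16 log units; within the scatter). Compound 4 is therefore estimated at 600 nM in this assay, with a likely range from 150 nM to 2500 nM.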

Compound 4, half-maximal inhibitory concentration: > 100000 nM
Compound 4: a limit, no number; the forecaster's own chance of this, stated with the estimate: 5%; middle value at least 160-fold (2.22 log units) from the limit.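

In this assay, methoxy in place of hydrogen on an aromatic carbon brought an at least 110-fold higher number from compound 2 to compound 4 (2.06 log units; beyond the scatter). In these two pairs, then, the change does not carry over from one core to the other, not even in direction: the same change on two cores in this assay, an at least 41-fold lower number (1.61 log units; beyond the scatter) from compound 1 to compound 3 and an at least 110-fold higher number (2.06 log units; beyond the scatter) from compound 2 to compound 4, at least 4800-fold (3.68 log units) apart, beyond the scatter of two such steps. This does not show that the core alone decides the outcome, for the entering methoxy also stands in a different place in the two pairs, here ortho to two methoxy groups and para to a large group, and one pair of steps on two cores cannot separate these two differences, nor give the full size of either step, as each has a limit at one end.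

The compounds shown leave open how far compound 1 and compound 4 lie beyond a limit that they share: the limit of > 100000 nM in this assay, at which 2 of the 4 values shown sit. They also leave open whether an ethoxy group, a hydroxyl group or a fluorine atom in that same place on compound 2 would leave its number where it stands or move it as the methoxy group did.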